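This account rests on a few compounds, and the source may have more. Where it says the series, first, only, none or still open, it means among the compounds named here.

Measured so far in a functional assay on V79 cells (Cricetulus griseus) for cytotoxicity, read by colony formation; on this read-out higher numbers stand for weaker inhibition and lower numbers for stronger inhibition:

compound 1 `CCNCC1CCN(c2cc3c(cc2F)c(=O)c(C(=O)O)cn3CC)C1` gives 310 ug/mL
compound 2 `COc1c(N2CCNCC2)c(F)cc2c(=O)c(C(=O)O)cn(C3CC3)c12` gives 82 ug/mL
compound 3 `Nc1c(F)c(N2CCC(N)C2)cc2c1c(=O)c(C(=O)O)cn2C1CC1` gives 54 ug/mL

Compound 3 and compound 2 lie within the scatter of each other, and together they sit at the low end of this small set. Compound 1 has a clearly higher number, beyond the scatter from compound 3.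

Compound 4 `CSc1c(F)c(N2CCC(N)C2)cc2c1c(=O)c(C(=O)O)cn2C1CC1` has not yet been measured. It differs from compound 3 by a single change, methylsulfanyl in place of amino on an aromatic carbon, ortho to a fluoro group and meta to a 3-aminopyrrolidin-1-yl group (methylsulfanyl in place of amino on an aromatic carbon).

Among the compounds with values here, no measured pair here isolates this swap, so the data do not fix its size. Within the data shown here, the only guidance is indirect. Compound 2 at 82 ug/mL and compound 3 at 54 ug/mL differ in several places yet stay within the scatter of each other, while compound 1 at 310 ug/mL shows how much wider the spread can be.

In this assay the estimated step is a 1.5-fold higher number from compound 3 to compound 4 (0.17 log units; within the scatter) and it is expected to point towards a higher number, probably within the scatter. For compound 4 the expected value is 80 ug/mL with an estimated range from 28 ug/mL to 230 ug/mL on this read-out.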

Compound 4, half-maximal inhibitory concentration: 92 ug/mL
Estimate against measurement, compound 4: 1.2-fold (0.06 log units) below; the range from low to high includes it.
By their numbers in this assay, from the lowest: compounds 3, 2 and 4 (each within the scatter of the next); then compound 1.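

Within the data shown here, compound 3 and compound 4 form the first pair in this set that differs in one place only, so the swap of amino for methylsulfanyl on an aromatic carbon, ortho to a fluoro group and meta to a 3-aminopyrrolidin-1-yl group, can now be read directly in this assay. It gives a 1.7-fold higher number from compound 3 to compound 4 (0.23 log units; within the scatter), so the two compounds cannot be told apart on this read-out, although the entering group has 2 heavy atoms and 0 hydrogen-bond donors where the leaving group has 1 heavy atom and 1 hydrogen-bond donor. Nothing shown here gives a reason for how close the two values lie.

What the compounds shown leave open is whether this position would stay as undemanding with a hydroxyl group, a methoxy group or a longer sulfur-linked chain such as ethylsulfanyl in place of the amino group. They also leave open whether the same swap would read the same way on the core of compound 1 or of compound 2, since this single pair rests on one side chain and one core.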